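The source may report more compounds than this note shows. Statements on the series, on what has been measured and on what is new or still open speak of the compounds shown alone.

Compound 1 `O=C1COC(c2ccc(/N=N/c3cccc(Cl)c3)cc2)=NN1` carries a 3-chlorophenyl group on a double-bonded nitrogen. In an assay on cells for inhibition of Amine oxidase [flavin-containing] A (Homo sapiens), read by Amplex Red, with a stated time of 30 min (a higher number here means a weaker inhibitor, a lower number a stronger inhibitor), compound 1 reaches only the limit of the assay, > 100000 nM, which is not a measured number. Compound 2 `O=C1COC(c2ccc(/N=N/c3ccc(Cl)cc3)cc2)=NN1` carries a 4-chlorophenyl group in the same place. In this assay compound 2 likewise stops at the limit, > 100000 nM. The step from compound 1 to compound 2 is a step that the two limits leave unreadable from compound 1 to compound 2. Both values sit at the limit of > 100000 nM in this assay, at which 2 of the 2 values shown sit, and compound 2 therefore stands at the limit in this assay, its true value unknown. Compound 3 `Cc1cccc(/N=N/c2ccc(C3=NNC(=O)CO3)cc2)c1` differs from compound 2 by 3-methylphenyl in place of 4-chlorophenyl on a double-bonded nitrogen. For the measured compounds named here, the single measured step, from compound 1 to compound 2, is itself unreadable and offers no size to lean on. Both measured compounds remain at the limit. Compound 3 is expected to remain there as well, with an estimated step that the limit leaves unreadable from compound 2 to compound 3. The estimate for compound 3 in this assay is 150000 nM, within a range from 30000 nM to 600000 nM.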

Compound 3, half-maximal inhibitory concentration: > 100000 nM
Compound 3: no number, only a limit; the forecaster's own chance of this, stated with the estimate: 80%; the middle value is on the limit's open side.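

In this assay compound 3 gives > 100000 nM, which is a limit of the assay and not a number. For the compounds shown here, no step among compound 1, compound 2 and compound 3 can be read, since all three stop at the same point: the limit of > 100000 nM in this assay, at which 3 of the 3 values shown sit. Going by these compounds, how far each compound's true value lies past that limit, and whether 3-chlorophenyl, 4-chlorophenyl and 3-methylphenyl differ at all, stays open.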